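Isopropyl on the amine nitrogen across two cores

This account rests on a few compounds, and the source may have more. Where it says the series, first, only, none or still open, it means among the compounds named here.

Compound 1 `N=C(N)c1ccc2cc(-c3cccc(OCCCCCOc4ccccc4)c3)oc2c1` and compound 2 `CC(C)NC(=N)c1ccc2cc(-c3cccc(OCCCCCOc4ccccc4)c3)oc2c1` share one core, while compound 3 `N=C(N)c1ccc2oc(-c3ccc(OCCCCOc4ccccc4)cc3)cc2c1` and the still unmeasured compound 4 `CC(C)NC(=N)c1ccc2oc(-c3ccc(OCCCCOc4ccccc4)cc3)cc2c1` share another. Within the data shown here, the difference between the two cores is not broken down here; within each pair only one change is made.

In an ADME assay on L6 cells (Rattus norvegicus) for cytotoxicity, read by resazurin assay, with a stated time of 70 h (on this read-out higher numbers stand for weaker inhibition and lower numbers for stronger inhibition), compound 1 gives 4100 nM. The change to compound 2 is isopropyl in place of hydrogen on an amine nitrogen, and in this assay compound 2 gives 20100 nM. That is a 4.9-fold higher number from compound 1 to compound 2 (0.69 log units; beyond the scatter).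

In this assay compound 3 gives 1300 nM, the lowest of the three measured numbers, with its gap to compound 1 beyond the scatter and its gap to compound 2 wider still. Compound 4 differs from compound 3 by isopropyl in place of hydrogen on an amine nitrogen, the same change at the same kind of place as between compound 1 and compound 2.

Among the measured compounds shown here, only one measured instance of this change exists, so the expectation for compound 4 rests on it alone: the step from compound 3 to compound 4 is expected to read a 4.9-fold higher number from compound 3 to compound 4 (0.69 log units; beyond the scatter), because a 4.9-fold higher number from compound 1 to compound 2 (0.69 log units; beyond the scatter) is the only guide to how this change moves the number. On that basis compound 4 is estimated at 6400 nM in this assay, with a likely range from 2500 nM to 16000 nM. The different core leaves room for the step to come out smaller or larger than in the first pair.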

Compound 4, half-maximal inhibitory concentration: 6900 nM
Beside the measured number, compound 4's estimate is 1.1-fold (0.03 log units) below it, and the stated range covers the measured number.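

In this assay, isopropyl in place of hydrogen on an amine nitrogen gives a 5.3-fold higher number from compound 3 to compound 4 (0.72 log units; beyond the scatter). Set beside the earlier step, the change carries from the core of compound 1 to the core of compound 3 with no difference in size that can be told apart, and the number rises on both: the same change on two cores in this assay, a 4.9-fold higher number (0.69 log units; beyond the scatter) from compound 1 to compound 2 and a 5.3-fold higher number (0.72 log units; beyond the scatter) from compound 3 to compound 4, 1.1-fold (0.03 log units) apart, within the scatter of two such steps. This agreement rests on two pairs in a single assay, so it supports carrying the step between these two cores only; it does not show that the step would hold on any other core or in any other assay, and it gives no reason for the rise.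

Open, going by these compounds, is how the number responds to other groups on the same amine nitrogen, such as methyl, ethyl, a cyclopentyl ring or a longer straight chain, and whether any of them would give a step of similar size to that of isopropyl. Also open, on these data alone, is whether the step keeps its size when the chain joining the two outer rings is changed on its own, for example to a shorter chain, or when a fluorine or a methoxy group is added to the terminal phenyl ring.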